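Bromopyrrole Chalcones Against KB403 Cells: An Unread Step

The source may hold more compounds than are shown below. What is called first, only, known or untested is meant among the compounds shown, and "the series" means these compounds.

compound 1 `Cn1c(/C=C/C(=O)c2ccccc2)cc(Br)c1Br`: >= 100000 nM, a limit of the assay
compound 2 `COc1ccc(C(=O)/C=C/c2cc(Br)c(Br)n2C)c(OC)c1`: >= 100000 nM, a limit of the assay
compound 3 `O=C(/C=C/c1cc(Br)c(Br)[nH]1)c1ccccc1`: >= 100000 nM, a limit of the assay

In a functional assay on KB403 cells (Homo sapiens) for cytotoxicity, read by MTT assay, with stated times of 6 h and 48 h (a lower number here means a stronger inhibitor, a higher number a weaker inhibitor), compound 1 reaches only the limit of the assay, >= 100000 nM. Compound 3 likewise stops at a limit, >= 100000 nM. Compound 2 also gives no number but a limit, >= 100000 nM. The step from compound 1 to compound 3, a step that the two limits leave unreadable from compound 1 to compound 3, is hydrogen in place of methyl on an aromatic nitrogen; both limits leave its size unreadable. Compound 2 and compound 1 differ in more than one place, and the difference between the two cores is not broken down here. Compound 4 `COc1ccc(C(=O)/C=C/c2cc(Br)c(Br)[nH]2)c(OC)c1` is not yet measured; it differs from compound 2 by hydrogen in place of methyl on an aromatic nitrogen, the same change, at the same place, as from compound 1 to compound 3. Because the limit of >= 100000 nM in this assay, at which 3 of the 3 values shown sit, holds for every compound shown, the chemist has no readable step to lean on. He expects the step from compound 2 to compound 4 to be a number no higher from compound 2 to compound 4 (the limit leaves the size open), resting on the unreadable a step that the two limits leave unreadable from compound 1 to compound 3 and on compound 2 sitting at the limit >= 100000 nM. For compound 4 in this assay he expects 100000 nM, estimated between 40000 nM and 300000 nM.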

Compound 4, half-maximal inhibitory concentration: >= 100000 nM
Compound 4 was reported as a limit; the forecaster's own chance of this, stated with the estimate: 85%; the middle value sits exactly at the limit.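

No size can be read for the step between compound 2 and compound 4, since both stop at a limit: the limit of >= 100000 nM in this assay, at which 4 of the 4 values shown sit. The compounds shown leave open whether hydrogen in place of methyl on the aromatic nitrogen changes cytotoxicity at all.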